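From Chloro to Bromo on the Outer Phenyl Ring

The source may hold more compounds than are shown below. What is called first, only, known or untested is meant among the compounds shown, and "the series" means these compounds.

Compound 1, `O=C(Nc1ccc(Oc2ccnc3[nH]ccc23)c(F)c1)c1cc(-c2ccccc2)ncn1`, gives 180 nM in a functional assay on A549 cells (Homo sapiens) for cytotoxicity, read by MTT assay, with a stated time of 72 h; a lower number here means a stronger inhibitor, a higher number a weaker inhibitor.
Compound 2, `COc1ccc(-c2cc(C(=O)Nc3ccc(Oc4ccnc5[nH]ccc45)c(F)c3)ncn2)cc1`, gives 4210 nM.
Compound 3, `O=C(Nc1ccc(Oc2ccnc3[nH]ccc23)c(F)c1)c1cc(-c2ccc(Cl)cc2)ncn1`, gives 3360 nM.

Compound 3 stands second highest of the three numbers: it lies within the scatter of compound 2, while a 19-fold higher number from compound 1 to compound 3 (1.27 log units; beyond the scatter). Compound 4, `O=C(Nc1ccc(Oc2ccnc3[nH]ccc23)c(F)c1)c1cc(-c2ccc(Br)cc2)ncn1`, differs from compound 3 by bromo in place of chloro on an aromatic carbon. Going by the values given here, no measured step exchanges chloro for bromo here. Among the compounds with values here, the steps that bear on it are a 19-fold higher number from compound 1 to compound 3 (1.27 log units; beyond the scatter) and a 1.3-fold lower number from compound 2 to compound 3 (0.10 log units; within the scatter): a group entering this position in place of hydrogen raised the number greatly, whereas trading one group for another at the same position stayed within the scatter. No step beyond the scatter is therefore expected in this assay, and a 1.0-fold higher number from compound 3 to compound 4 (0.02 log units; within the scatter) is the expected outcome. Compound 4 is estimated at 3500 nM, between 1500 nM and 8000 nM.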

Compound 4, half-maximal inhibitory concentration: 6980 nM
Compound 4: the middle estimate sits 2.0-fold (0.30 log units) below what was measured; the measured number falls inside the stated range.
By their numbers in this assay, from the lowest: compound 1; then compounds 3, 2 and 4 (each within the scatter of the next, the first and the last beyond it).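

In this assay, going by these compounds alone, the two halogens are not interchangeable at this position: the exchange shows a 2.1-fold higher number from compound 3 to compound 4 (0.32 log units; beyond the scatter), the only swap between groups here that passes the scatter, while a 1.7-fold higher number from compound 2 to compound 4 (0.22 log units; within the scatter) stays within it. The larger gap remains the one from hydrogen, with a 39-fold higher number from compound 1 to compound 4 (1.59 log units; beyond the scatter). Nothing available explains either step. Open, as far as these compounds go, is whether fluoro, an amine or a carboxylic acid in this place would stay with compound 2, compound 3 and compound 4 or come back toward compound 1.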